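The source may report more compounds than this note shows. Statements on the series, on what has been measured and on what is new or still open speak of the compounds shown alone.

Measured compounds in a functional assay on SF-539 cells (Homo sapiens) for inhibition; a higher number here means a weaker inhibitor of growth, a lower number a stronger inhibitor of growth:
compound 1 `COc1cc(/C=C/C(=O)c2cccc(-n3cc(-c4ccccc4)[nH]c3=O)c2)ccc1O`, 1910 nM
compound 2 `O=C(/C=C/c1cccc(O)c1)c1cccc(-n2cc(-c3ccccc3)[nH]c2=O)c1`, 1980 nM
compound 3 `COc1cc(/C=C/C(=O)c2cccc(-n3cc(-c4ccccc4)[nH]c3=O)c2)cc(OC)c1OC`, 1680 nM

Compound 3 has the lowest number of the three, but its gap to compound 1 and to compound 2 lies within the scatter, so no order among the three can be read from this assay. Within the data shown here, the only single-point step measured so far, a 1.0-fold higher number from compound 1 to compound 2 (0.02 log units; within the scatter), alters the aryl on the double-bonded chain and leaves the number where it was.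

Compound 4 `COc1ccc(-c2cn(-c3cccc(C(=O)/C=C/c4cc(OC)c(OC)c(OC)c4)c3)c(=O)[nH]2)cc1` differs from compound 3 in methoxy in place of hydrogen on an aromatic carbon. Among the measured compounds shown here, this change sits on the other side of the shared core, on the phenyl bound to the heterocycle, a position no measured pair has touched. For the measured compounds named here, nothing measured bears directly on it; the only indirect guide is that the series has so far been flat to substitution on the aryl of the chain. On that basis no step beyond the scatter is expected in this assay: compound 4 is estimated at 1700 nM, range 750 nM to 3800 nM, a step of a 1.0-fold higher number from compound 3 to compound 4 (0.01 log units; within the scatter) expected from compound 3 to compound 4.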

Compound 4, concentration for 50% growth inhibition: 2000 nM
The estimate for compound 4 lay 1.2-fold (0.07 log units) below the measured number, within the range that was stated.
By their numbers in this assay, from the lowest: compounds 3, 1, 2 and 4 (each within the scatter of the next).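

In this assay, among these compounds, the exchange of phenyl for 4-methoxyphenyl gives a 1.2-fold higher number from compound 3 to compound 4 (0.08 log units; within the scatter) and provides the first reading at this position, on an aromatic carbon para to a large group. This aromatic carbon therefore accepts methoxy in place of hydrogen without a step beyond the scatter, so the flat reading seen on the chain aryl between compound 1 and compound 2 now has a counterpart on the phenyl of the shared core. No measured information is available to explain this result.

Methoxy is the only group read here, so it remains open whether an amine, a carboxylic acid or a longer chain such as butoxy at this carbon would move the number in this assay. Neither listed step lies beyond the scatter, so the compounds shown do not yet identify a change to which this assay responds.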